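Para-substituted analogues in the P388 cytotoxicity series

The compounds below may be only part of what the source reports. "The series", "measured", "known", "first", "only" and "open" are said of these compounds alone.

Values in a functional assay on P388 cells (Mus musculus) for cytotoxicity; on this read-out lower numbers stand for stronger inhibition and higher numbers for weaker inhibition:
- compound 1 `COc1ccc2cc1Oc1ccc(cc1)C[C@H]1C(=O)N(C)[C@@H](C2)C(=O)N[C@H](C)C(=O)N[C@@H](C)C(=O)N(C)[C@@H](Cc2ccccc2)C(=O)N[C@@H](C)C(=O)N1C` gives 295 nM
- compound 2 `C=Cc1ccc(C[C@H]2C(=O)N[C@@H](C)C(=O)N(C)[C@H]3Cc4ccc(cc4)Oc4cc(ccc4OC)C[C@@H](C(=O)N[C@H](C)C(=O)N[C@@H](C)C(=O)N2C)N(C)C3=O)cc1` gives 17 nM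
- compound 3 `CCc1ccc(C[C@H]2C(=O)N[C@@H](C)C(=O)N(C)[C@H]3Cc4ccc(cc4)Oc4cc(ccc4OC)C[C@@H](C(=O)N[C@H](C)C(=O)N[C@@H](C)C(=O)N2C)N(C)C3=O)cc1` gives 9.33 nM

Compound 3 stands well under compound 1, as shown by a 32-fold lower number from compound 1 to compound 3 (1.50 log units; beyond the scatter). The vinyl analogue shows a similar large change, a 17-fold lower number from compound 1 to compound 2 (1.24 log units; beyond the scatter). The pair itself stays within the scatter, with a 1.8-fold lower number from compound 2 to compound 3 (0.26 log units; within the scatter). Compound 4 `C/C=C/c1ccc(C[C@H]2C(=O)N[C@@H](C)C(=O)N(C)[C@H]3Cc4ccc(cc4)Oc4cc(ccc4OC)C[C@@H](C(=O)N[C@H](C)C(=O)N[C@@H](C)C(=O)N2C)N(C)C3=O)cc1` follows from prop-1-en-1-yl in place of ethyl on an aromatic carbon, which puts prop-1-en-1-yl in place of ethyl on an aromatic carbon. Among the compounds with values here, no measured compound carries prop-1-en-1-yl, so the vinyl and ethyl steps are the only guide. In this assay, going by these compounds, no change beyond the scatter is expected, and the direction stays open. The estimated step is a 1.5-fold higher number from compound 3 to compound 4 (0.18 log units; within the scatter). Compound 4 is expected at 14 nM, with an estimated range of 5 nM to 45 nM.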

Compound 4, half-maximal inhibitory concentration: 5.01 nM
For compound 4 the middle estimate is 2.8-fold (0.45 log units) above the measured one; measured number inside the range.
By their numbers in this assay, from the lowest: compounds 4, 3 and 2 (each within the scatter of the next, the first and the last beyond it); then compound 1.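

In this assay, prop-1-en-1-yl on the aromatic carbon para to a large group stays level with ethyl (a 1.9-fold lower number from compound 3 to compound 4 (0.27 log units; within the scatter)). It does separate from vinyl (a 3.4-fold lower number from compound 2 to compound 4 (0.53 log units; beyond the scatter)), although vinyl and ethyl themselves could not be told apart. The gain over the unsubstituted compound also extends to this group (a 59-fold lower number from compound 1 to compound 4 (1.77 log units; beyond the scatter)), so this position accepts at least this group without loss of activity relative to ethyl.

Going by these compounds, whether a longer chain such as butyl, an amine or a carboxylic acid on this carbon would hold this level stays open. The data shown do not explain these differences. No evidence on them is available here.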